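The source may report more compounds than this note shows. Statements on the series, on what has been measured and on what is new or still open speak of the compounds shown alone.

Three compounds share one core and differ only in the arm that hangs from the amine. Compound 1 `O=S(=O)(NCCCCNCc1ccc(Br)cc1)c1cc(C(F)(F)F)cc(C(F)(F)F)c1` carries a bromo group on a benzyl arm and has a longer chain between the core and the amine; in a functional assay on ASPC1 cells (Homo sapiens) for inhibition, read by MTT assay, with a stated time of 72 h (a lower number here means a stronger inhibitor of growth, a higher number a weaker inhibitor of growth), compound 1 gives 2900 nM. Compound 2 `COc1ccc(CNCCCNS(=O)(=O)c2cc(C(F)(F)F)cc(C(F)(F)F)c2)cc1OC` carries two methoxy groups on a shorter chain, and in this assay compound 2 gives 6400 nM. Compound 3 `O=S(=O)(NCCCNCc1ccc(-c2ccccc2)cc1)c1cc(C(F)(F)F)cc(C(F)(F)F)c1` carries a phenyl group, and in this assay compound 3 gives 2500 nM, the lowest of the three numbers. Compound 1 sits closest to it, within the usual scatter, while compound 2 lies further off, beyond the scatter.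

Compound 4 `O=S(=O)(NCCCNCc1ccc(Br)cc1)c1cc(C(F)(F)F)cc(C(F)(F)F)c1` arises from compound 3 by a single exchange: bromo in place of phenyl on an aromatic carbon. Among the measured compounds shown here, no pair of measured compounds isolates this exchange on its own. The nearest guide is compound 1, which carries the same bromo group on a longer chain and gives 2900 nM, a number within the scatter of compound 3. On that basis the step of a 1.2-fold higher number from compound 3 to compound 4 (0.08 log units; within the scatter) is expected to be small, with no movement beyond the scatter in either direction. Compound 4 is therefore estimated to give 3000 nM, with a likely range from 1500 nM to 6500 nM.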

Compound 4, concentration for 50% growth inhibition: 2800 nM
Beside the measured number, compound 4's estimate is 1.1-fold (0.03 log units) above it; low and high end bracket the measured number.
By their numbers in this assay, from the lowest: compounds 3, 4 and 1 (each within the scatter of the next); then compound 2.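

Exchanging a whole phenyl ring for a single bromo group at this spot, para to a large group, gives a 1.1-fold higher number from compound 3 to compound 4 (0.05 log units; within the scatter) in this assay, so a large gain or loss in this read-out does not follow from such a change in size of the group at this position. With the bromo group held fixed, shortening the chain gives a 1.0-fold lower number from compound 1 to compound 4 (0.02 log units; within the scatter) and leaves the number within the scatter, whereas 4-bromophenyl in place of 3,4-dimethoxyphenyl gives a 2.3-fold lower number from compound 2 to compound 4 (0.36 log units; beyond the scatter) as a modest step and the only new one beyond the scatter, which shows that changing the aromatic end of the arm can move the number even though phenyl and bromo at this position do not separate. No measurement is available that would explain why phenyl and bromo read alike here.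

As far as these compounds go, what a plain hydrogen, a fluoro group or a carboxylic acid on that aromatic carbon would give remains open, so whether this position needs any group at all cannot be said. Also open, from the compounds shown here alone, is how a much longer chain would behave with the bromo group in place.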